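A Larger Ring Carrying the Same Amide

The source may hold more compounds than are shown below. What is called first, only, known or untested is meant among the compounds shown, and "the series" means these compounds.

Compound 2 `N#Cc1cnc(NCc2ccccc2C(F)(F)F)cc1N[C@H]1C[C@H](C(N)=O)C1` carries a 3-carbamoylcyclobutyl group on a nitrogen on an aromatic ring. In an assay on isolated protein for inhibition of protein kinase C delta type (Homo sapiens), read by TR-FRET, with a stated time of 2 h (a lower number here means a stronger inhibitor, a higher number a weaker inhibitor), compound 2 reaches only the limit of the assay, > 10000 nM. Compound 1 `N#Cc1cnc(NCc2ccccc2C(F)(F)F)cc1N[C@H]1CC[C@H](O)CC1` likewise stops at the limit, > 10000 nM. The step that the two limits leave unreadable from compound 1 to compound 2 is thus of unknown size. Compound 3 `N#Cc1cnc(NCc2ccccc2C(F)(F)F)cc1N[C@H]1CC[C@@H](C(N)=O)CC1` differs from compound 2 by 4-carbamoylcyclohexyl in place of 3-carbamoylcyclobutyl on a nitrogen on an aromatic ring. Both measured values rest at the same limit (the limit of > 10000 nM in this assay, at which 2 of the 2 values shown sit), which shows no direction for this change. Compound 3 is therefore expected to move by about a step that the limit leaves unreadable from compound 2 to compound 3, no readable step. The estimate for compound 3 is 15000 nM, within 3000 nM to 60000 nM.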

Compound 3, half-maximal inhibitory concentration: 640 nM
Compound 3: the middle estimate sits 23-fold (1.37 log units) above what was measured, and the stated range ends above it.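

In this assay, changing the ring on this nitrogen gives the first readable result: an at least 15-fold lower number from compound 2 to compound 3 (1.19 log units; beyond the scatter). With the six-membered ring kept, replacing the hydroxyl with the amide also matters: an at least 15-fold lower number from compound 1 to compound 3 (1.19 log units; beyond the scatter). Both sizes are only minimums, because compound 1 and compound 2 stop at a limit of the assay: the limit of > 10000 nM in this assay, at which 2 of the 3 values shown sit.

The compounds shown leave open whether a carboxylic acid or an amine at the 4-position of the cyclohexyl ring would match the amide. They also leave open how a five-membered ring carrying the same amide would compare.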